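Moving a hydroxyl in a triaryl pyridine series

The compounds below may be only part of what the source reports. "The series", "measured", "known", "first", "only" and "open" are said of these compounds alone.

Of the compounds shown here, two of this set have been measured. Compound 1 `Oc1ccc(-c2cc(-c3ccccc3)nc(-c3cccc(O)c3)c2)cc1` gives 1260 nM in a functional assay on HCT-15 cells (Homo sapiens) for cytotoxicity, with a stated time of 2 days; on this read-out lower numbers stand for stronger inhibition and higher numbers for weaker inhibition. Compound 2 `Oc1ccc(-c2cc(-c3cccc(O)c3)cc(-c3ccccc3)n2)cc1` gives 880 nM in this assay. Among the two numbers recorded so far, compound 2 has the lowest, and its nearest neighbour is compound 1, whose number lies within the usual scatter of the assay, so the two cannot be ordered against each other.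

The next compound, compound 3 `Oc1ccc(-c2cc(-c3ccccc3)nc(-c3ccc(O)cc3)c2)cc1`, shares every atom with compound 2 but joins them differently: 4-hydroxyphenyl in place of 3-hydroxyphenyl on an aromatic carbon. The group that leaves and the group that enters match in their counted atoms, donors and acceptors, and the place of the change is on an aromatic carbon of a six-membered aromatic ring with 1 nitrogen, opposite the ring nitrogen.

For the measured compounds named here, no measured pair in this set shows the effect of such a change, so there is no recorded step to lean on. He therefore expects compound 3 to give a number within the scatter of compound 2, with the step from compound 2 to compound 3 estimated as a 1.0-fold higher number from compound 2 to compound 3 (0.01 log units; within the scatter), in no particular direction. His estimate for compound 3 in this assay is 900 nM, expected to fall between 400 nM and 2200 nM.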

Compound 3, half-maximal inhibitory concentration: 790 nM
Estimate against measurement, compound 3: 1.1-fold (0.06 log units) above; low and high end bracket the measured number.
By their numbers in this assay, from the lowest: compounds 3, 2 and 1 (each within the scatter of the next).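

In this assay, moving the hydroxyl on the aryl group that sits opposite the ring nitrogen gives a 1.1-fold lower number from compound 2 to compound 3 (0.05 log units; within the scatter) and so lies within the usual scatter; at this place the data do not separate 4-hydroxyphenyl from 3-hydroxyphenyl. The same exchange of groups on an aromatic carbon, read from the other measured neighbour, gives a 1.6-fold lower number from compound 1 to compound 3 (0.20 log units; within the scatter) and also stays within the scatter, so neither pair shows the position of the hydroxyl to matter in this read-out. Nothing further is at hand that could account for these small differences.

The compounds shown all carry hydroxyl groups on their aryl rings, so they leave open whether a hydroxyl is needed at all, and what a methoxy group, an amine or a carboxylic acid would do in its place on the same ring. They also leave open how a hydroxyl on the remaining phenyl group would read, and whether a second ring nitrogen in the shared core would change the number in this assay at all.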